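The source may report more compounds than this note shows. Statements on the series, on what has been measured and on what is new or still open speak of the compounds shown alone.

Compound 1 `O=C(CN1CCN(c2nnc(Cc3ccncc3)c3ccccc23)CC1)Nc1ccc(Br)cc1` combines a pyridin-4-ylmethyl group on the shared core with an amide to a bromine-bearing phenyl ring. In a functional assay on HT-29 cells (Homo sapiens) for cytotoxicity, read by MTT assay, with a stated time of 72 h (a lower number here means a stronger inhibitor, a higher number a weaker inhibitor), compound 1 gives 1990 nM, the lowest number among the two compounds that returned one. Compound 3 `Cc1ccccc1NC(=O)CN1CCN(c2nnc(Cc3ccccc3)c3ccccc23)CC1` carries a benzyl group in place of the pyridin-4-ylmethyl and a methyl-bearing phenyl amide, and in this assay compound 3 gives 113000 nM, far beyond the scatter from compound 1. Compound 2 `Cc1ccc(NC(=O)CN2CCN(c3nnc(Cc4ccccc4)c4ccccc34)CC2)c(C)c1` is the benzyl analogue with a phenyl amide carrying two methyl groups, and in this assay compound 2 gives "not active" (no number reported). Since compounds 2 and 3 differ from compound 1 in two places at once, neither shows what the benzyl group alone does.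

Compound 4 `O=C(CN1CCN(c2nnc(Cc3ccccc3)c3ccccc23)CC1)Nc1ccc(Br)cc1` keeps the amide of compound 1 and changes only the other arm: phenyl in place of pyridin-4-yl on a saturated chain carbon bound to an aromatic carbon. Going by the values given here, no measured pair isolates this exchange. Both benzyl compounds that have been tested are weak, so a rise in the number beyond the scatter seems the more probable outcome, though the amide differences leave this uncertain. For compound 4 the value in this assay is estimated at 10000 nM, within a range from 2000 nM to 60000 nM, corresponding to an expected step of a 5.0-fold higher number from compound 1 to compound 4 (0.70 log units; beyond the scatter).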

Compound 4, half-maximal inhibitory concentration: 60200 nM
The estimate for compound 4 lay 6.0-fold (0.78 log units) below the measured number; the measured number lies above the stated range.
By their numbers in this assay, from the lowest: compound 1; then compounds 4 and 3 (each within the scatter of the next).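

With the amide to the 4-bromophenyl ring held fixed, putting phenyl in place of pyridin-4-yl on a saturated chain carbon bound to an aromatic carbon gives a 30-fold higher number from compound 1 to compound 4 (1.48 log units; beyond the scatter) in this assay, so this position responds strongly to a change of a single ring atom, from nitrogen to carbon. With the benzyl group held fixed, 4-bromophenyl in place of 2-methylphenyl on an amide-type nitrogen gives a 1.9-fold lower number from compound 3 to compound 4 (0.27 log units; within the scatter), so this amide exchange shows no clear effect, and the low number of compound 1 cannot be credited to its 4-bromophenyl amide alone, since compound 4 carries the same amide. Nothing available here explains why the pyridin-4-yl group makes this difference.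

The compounds shown leave open whether the ring nitrogen must sit where it does in pyridin-4-yl, a question that pyridin-3-yl or pyridin-2-yl on the same chain carbon could answer. They also leave open whether pyridin-4-yl has a similar effect when paired with the 2-methylphenyl amide instead of the 4-bromophenyl amide.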